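Nucleoside series: benzylamino to dimethylamino at the ring carbon

The source may report more compounds than this note shows. Statements on the series, on what has been measured and on what is new or still open speak of the compounds shown alone.

Measured so far in a functional assay (Homo sapiens) for inhibition of Nucleic Acid, tested at 100 uM; on this read-out lower numbers stand for less inhibition and higher numbers for more inhibition at the one concentration tested (going by the name of the read-out):
- compound 1 `OC[C@H]1O[C@@H](n2cnc3c(NCc4ccccc4)nccc32)C[C@@H]1O` gives 15%
- compound 2 `Sc1[nH]ccc2ncnc1-2` gives 26%

Compound 1 stands lowest of the two numbers in this assay; compound 2 lies higher by a gap beyond the scatter. For the measured compounds named here, no pair of measured compounds differs in a single place, so no step size is established in this assay.

Compound 3 `CN(C)c1nccc2c1ncn2[C@H]1C[C@H](O)[C@@H](CO)O1` is unmeasured. Against compound 1 the change is dimethylamino in place of benzylamino on an aromatic carbon: dimethylamino in place of benzylamino, on an aromatic carbon of a six-membered aromatic ring with one nitrogen, part of a fused system of two rings, next to the ring nitrogen.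

Going by the values given here, with no measured step to lean on, the expected step in this assay from compound 1 to compound 3 is no change at the digits printed from compound 1 to compound 3 (within the scatter), which is within the scatter. Compound 3 is estimated at 15%, with a range from 3% to 30%.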

Compound 3, a percentage reported as inhibition, at one concentration (the size of the read-out at that concentration, not a potency): 0%
Compound 3: the middle estimate sits 15 percentage points above what was measured; the measured number lies below the stated range.
By their numbers in this assay, from the lowest: compound 3; then compound 1; then compound 2.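

In this assay, for the compounds shown here, the swap of benzylamino for dimethylamino on this aromatic carbon gives the first measured step, a number 15 percentage points lower from compound 1 to compound 3 (beyond the scatter), so the group at this position does affect the read-out. The change removes the six-membered aromatic ring of carbon only and the hydrogen-bond donor together, and this single pair cannot separate the two. Nothing measured here bears on why the number falls.

On these data alone, whether the step follows the loss of the ring, the loss of the donor or the shorter substituent remains open. Methylamino on the same aromatic carbon would keep the donor without the ring, while phenethylamino would keep both on a longer chain, and either would show how far the step depends on each part.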